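This account rests on a few compounds, and the source may have more. Where it says the series, first, only, none or still open, it means among the compounds named here.

Working notes on the series. Compound 1 `COc1ccc2c(c1)NC(=O)CN2c1nc(NCCCO)nc2ccccc12` gives 5.18 nM in a functional assay on A549 cells (Homo sapiens) for inhibition, read by sulforhodamine B assay, with a stated time of 48 h (a lower number here means a stronger inhibitor of growth, a higher number a weaker inhibitor of growth), the lowest of the three numbers measured. Compound 3 `COc1ccc2c(c1)NC(=O)CN2c1nc(Nc2ccc(C#N)cc2)nc2ccccc12` gives 6.17 nM, which is a 1.2-fold higher number from compound 1 to compound 3 (0.08 log units; within the scatter). Compound 2 `COc1ccc2c(c1)NC(=O)CN2c1nc(OCC2CC2)nc2ccccc12` gives 15.8 nM, a 3.1-fold higher number from compound 1 to compound 2 (0.48 log units; beyond the scatter), and from compound 2 the number drops again, a 2.6-fold lower number from compound 2 to compound 3 (0.41 log units; beyond the scatter).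

Compound 4 `COc1ccc2c(c1)NC(=O)CN2c1nc(COC(C)=O)nc2ccccc12` is not yet measured. Relative to compound 1 the change is acetoxymethyl in place of (3-hydroxypropyl)amino on an aromatic carbon. Going by the values given here, the step bearing most directly on this is the one to compound 2, where the (3-hydroxypropyl)amino on the same aromatic carbon was also replaced by a group without hydrogen-bond donors and with no nitrogen link, and the number rose modestly, a 3.1-fold higher number from compound 1 to compound 2 (0.48 log units; beyond the scatter). The step to compound 3 kept an amino link and stayed within the scatter, a 1.2-fold higher number from compound 1 to compound 3 (0.08 log units; within the scatter). A modest rise is therefore expected for compound 4, a 2.9-fold higher number from compound 1 to compound 4 (0.46 log units; beyond the scatter), probably beyond the scatter. The estimate for compound 4 is 15 nM, with a range of 6 nM to 40 nM.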

Compound 4, concentration for 50% growth inhibition in the A549 assay: 5.52 nM
Compound 4: middle estimate off by 2.7-fold (0.43 log units), on the high side, and the stated range ends above it.
By their numbers in the A549 assay, from the lowest: compounds 1, 4 and 3 (each within the scatter of the next); then compound 2.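

In the A549 assay the acetoxymethyl group, with no nitrogen link and without hydrogen-bond donors, matches both the (3-hydroxypropyl)amino group, a 1.1-fold higher number from compound 1 to compound 4 (0.03 log units; within the scatter), and the (4-cyanophenyl)amino group, a 1.1-fold lower number from compound 3 to compound 4 (0.05 log units; within the scatter), so at this aromatic carbon neither the amino link nor a hydrogen-bond donor is required for the number. Cyclopropylmethoxy alone stands apart, a 2.9-fold lower number from compound 2 to compound 4 (0.46 log units; beyond the scatter), so the rise it showed cannot be read as the loss of the amino link. In a physicochemical assay for solubility, read by HPLC, at pH 7.4 (a lower number here means a less soluble compound, a higher number a more soluble compound), compound 1 gives 80.9 ug/mL and compound 4 gives 8.07 ug/mL, so a change that is silent for growth inhibition still lowers solubility: the measured solubility of compound 1, 80.9 ug/mL, and of compound 4, 8.07 ug/mL, a 10-fold lower number (1.00 log units; beyond the scatter)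

On these data alone, whether a hydroxymethyl group or a morpholine at this carbon would keep the number in the A549 assay while restoring solubility remains open. So does whether any other ester behaves like acetoxymethyl.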